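The source may report more compounds than this note shows. Statements on the series, on what has been measured and on what is new or still open speak of the compounds shown alone.

Measured in an ADME assay on microsomes (Homo sapiens) for metabolic stability; a higher number here means faster removal of the compound, a lower number slower removal:
- compound 1 `CNC(=O)[C@@H]1CCCN1S(=O)(=O)c1cccc(COc2cccc3c(C(F)(F)F)cc(C)nc23)c1`: 50 mL/min/kg
- compound 2 `COC[C@@H]1CCCN1S(=O)(=O)c1ccc(Cl)c(COc2cccc3c(C(F)(F)F)cc(C)nc23)c1Cl`: 450 mL/min/kg
- compound 3 `CNC(=O)[C@@H]1CCCN1S(=O)(=O)c1ccc(Cl)c(COc2cccc3c(-c4cncn4C)cc(C)nc23)c1Cl`: 33.3 mL/min/kg

Compound 3 sits at the low end of these three numbers. Its value and that of compound 1 lie within the scatter of each other, while compound 2 stands higher, beyond the scatter. Compound 1 and compound 3 share the methyl amide side chain and compound 2 does not, but these compounds also differ elsewhere, so three numbers cannot separate the contributions.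

Compound 4 `CNC(=O)[C@@H]1CCCN1S(=O)(=O)c1ccc(Cl)c(COc2cccc3c(-c4ccccn4)cc(C)nc23)c1Cl` has pyridin-2-yl in place of 1-methyl-1H-imidazol-5-yl on an aromatic carbon of compound 3 (pyridin-2-yl in place of 1-methyl-1H-imidazol-5-yl on an aromatic carbon). Within the data shown here, no measured pair isolates this change, so its size in this assay is not known from the data. Compound 4 keeps the methyl amide side chain, so the expectation starts from compound 3 at 33.3 mL/min/kg and not from the much higher number of compound 2. A modest upward step is expected, with the estimate being a 1.8-fold higher number from compound 3 to compound 4 (0.26 log units; within the scatter). The estimated value for compound 4 is 60 mL/min/kg, with an expected range of 28 mL/min/kg to 130 mL/min/kg.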

Compound 4, clearance: 183 mL/min/kg
Beside the measured number, compound 4's estimate is 3.1-fold (0.48 log units) below it, outside the stated range (above it).
By their numbers in this assay, from the lowest: compounds 3 and 1 (each within the scatter of the next); then compound 4; then compound 2.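

In this assay, among these compounds, pyridin-2-yl in place of 1-methyl-1H-imidazol-5-yl on the aromatic carbon opposite the ring nitrogen gives a 5.5-fold higher number from compound 3 to compound 4 (0.74 log units; beyond the scatter), the first comparison that isolates a single place. The position is therefore not silent: with the rest of the molecule unchanged, including the methyl amide side chain, the choice of aromatic ring at this carbon alone moves the number beyond the scatter. No measurement here bears on why this exchange has such an effect, so the step stands as an observation only.

The exchange changes ring size, hetero atom count and the presence of the methyl group all at once, so a single pair cannot say which of these matters; phenyl, pyridin-3-yl or 1H-imidazol-5-yl at this carbon would begin to separate them. Also open, on these data alone, is whether the step keeps its size on a different side chain, such as the methoxymethyl group of compound 2, or on a core without the two chlorine atoms, as in compound 1.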